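The compounds below may be only part of what the source reports. "The series", "measured", "known", "first", "only" and "open" are said of these compounds alone.

Measured so far:
- compound 1 `CCc1cnc(N2CCC(c3coc4c(N5CCc6cc(S(C)(=O)=O)ccc65)ncnc34)CC2)nc1` — 41 nM
- compound 2 `CC(C)(C)OC(=O)N1CCC(c2noc3c(Nc4ccc(S(C)(=O)=O)cc4F)ncnc23)CC1` — 353 nM

Two compounds have been run in a functional assay on cells for agonist activity at Glucose-dependent insulinotropic receptor (Homo sapiens), read by a luciferase reporter, with a stated time of 4 h; on this read-out lower numbers stand for an effect already at smaller amounts and higher numbers for an effect only at larger amounts of compound. Compound 1 stands at the lowest of the two numbers, and compound 2 sits at a markedly higher value, a gap well beyond the usual scatter. The two compounds differ in several places at once, so no single step can be read from them.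

Compound 3 `CC(C)(C)OC(=O)N1CCC(c2coc3c(N4CCc5cc(S(C)(=O)=O)ccc54)ncnc23)CC1` is the next point and is not yet measured. It differs from compound 1 in one place only: tert-butoxycarbonyl in place of 5-ethylpyrimidin-2-yl on an amine nitrogen in a ring. The same tert-butoxycarbonyl group is present in compound 2, which gives 353 nM, but on a different core; that pairing is the only hint available. Given this, a step from compound 1 to compound 3 of a 7.3-fold higher number from compound 1 to compound 3 (0.86 log units; beyond the scatter) towards higher values is expected, beyond the scatter. Compound 3 is accordingly expected to give 300 nM, within a range of 80 nM to 1500 nM.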

Compound 3, half-maximal effective concentration: 53 nM
Compound 3: the middle estimate sits 5.7-fold (0.75 log units) above what was measured; measured number below the stated range.
By their numbers in this assay, from the lowest: compounds 1 and 3 (each within the scatter of the next); then compound 2.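

In this assay, tert-butoxycarbonyl in place of 5-ethylpyrimidin-2-yl on the amine nitrogen in a ring gives a 1.3-fold higher number from compound 1 to compound 3 (0.11 log units; within the scatter) and so leaves the two groups indistinguishable on the core of compound 1. At this position, a six-membered aromatic ring with 2 hetero atoms is therefore not needed to keep the read-out of compound 1, since a group with no ring does as well in this pair. Nothing measured here explains why the two groups read alike.

On these data alone, it remains open whether this tolerance extends to quite different groups on the same nitrogen, such as a plain methyl, an acetyl or a chain ending in a carboxylic acid. Also open, as far as these compounds go, is whether the same exchange would read alike on any other core.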